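The compounds below may be only part of what the source reports. "The series", "measured", "known", "first", "only" and "open" are said of these compounds alone.

Measured so far in an assay on brain for displacement of a labelled ligand from 5-hydroxytryptamine receptor 4 (Cavia porcellus), with a stated time of 30 min, in the presence of a further agent that is not named here; a lower number here means a stronger inhibitor, a higher number a weaker inhibitor:
compound 1 `COc1cc(N)c(Cl)cc1C(=O)CCC1CCN(CCNS(=O)(=O)c2ccc(NC(C)=O)cc2)CC1` gives 7.7 nM
compound 2 `COc1cc(N)c(Cl)cc1C(=O)CCC1CCN(CCNS(=O)(=O)c2ccc(OC)c(N3CCN(C)CC3)c2)CC1` gives 3.46 nM

Compound 1 holds the higher of the two numbers; compound 2 stands at a lower number, and the gap between them lies beyond the usual scatter. Compound 3 `COc1cc(N)c(Cl)cc1C(=O)CCC1CCN(CCNS(=O)(=O)c2ccc(N)c(Br)c2)CC1` is not yet measured. Relative to compound 1 it differs as follows: 4-amino-3-bromophenyl in place of 4-acetamidophenyl on a sulfonyl sulfur. Going by the values given here, no measured pair in this set tracks such a change, so the step cannot be read off from the data. A small step is expected, in either direction, not clearly beyond the scatter. Compound 3 is estimated at 5 nM, within 1.5 nM to 16 nM, the expected step being a 1.5-fold lower number from compound 1 to compound 3 (0.19 log units; within the scatter).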

Compound 3, inhibition constant: 5.3 nM
The estimate for compound 3 lay 1.1-fold (0.03 log units) below the measured number; the range from low to high includes it.
By their numbers in this assay, from the lowest: compounds 2, 3 and 1 (each within the scatter of the next, the first and the last beyond it).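

In this assay, the exchange of 4-acetamidophenyl for 4-amino-3-bromophenyl on a sulfonyl sulfur gives a 1.5-fold lower number from compound 1 to compound 3 (0.16 log units; within the scatter) and so leaves the affinity within the scatter. At this position, the acetamide can therefore give way to a free amino group with bromine also on the ring, with no loss beyond the scatter. Nothing at hand gives a reason for this result.

From the compounds shown here alone, the acetamide and bromine changes arrive together, so their separate contributions remain open. A plain 4-aminophenyl group, or a 4-amino-3-chlorophenyl group, would help to separate them.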